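The source may hold more compounds than are shown below. What is called first, only, known or untested is meant among the compounds shown, and "the series" means these compounds.

Measured compounds:
compound 1 `Cc1cccc(/C(N)=N/NC(=S)N2CCN(c3ccccn3)CC2)n1` 850 nM
compound 2 `N/C(=N\NC(=S)N1CCCCCC1)c1ccccn1` 740 nM
compound 3 `N/C(=N\NC(=S)N1CCSCC1)c1ccccn1` 760 nM

Among the compounds with values here, the three measured members have been run in a functional assay on A-375 cells (Homo sapiens) for cytotoxicity, read by MTT assay, with a stated time of 72 h (a lower number here means a stronger inhibitor, a higher number a weaker inhibitor), and in that readout compound 1 gives 850 nM, compound 2 gives 740 nM and compound 3 gives 760 nM. Within the data shown here, compound 2 has the lowest of the three numbers, but the gaps to compound 3 and to compound 1 both lie within the usual scatter of repeated measurements, so the three values cannot be ranked against one another; the series so far looks flat in this assay.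

The next compound, compound 4 `Cc1ccnc(/C(N)=N/NC(=S)N2CCCCCC2)c1`, is not yet measured. Relative to compound 2 it carries one change, methyl in place of hydrogen on an aromatic carbon, meta to a large group and opposite the ring nitrogen. Among the measured compounds shown here, no pair of measured compounds differs in one place only, so no step of this kind has been observed directly. Compound 1 does carry a methyl on the same ring, though at a different place and with a different amine, and its value sits within the scatter of compound 2, which gives no sign that a methyl on this ring moves the number. The expectation for the step from compound 2 to compound 4 is therefore a 1.1-fold higher number from compound 2 to compound 4 (0.03 log units; within the scatter), no change beyond the scatter in either direction. Compound 4 is estimated at 800 nM, with a range from 400 nM to 1600 nM.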

Compound 4, half-maximal inhibitory concentration: 800 nM
Compound 4: middle estimate and measured number agree at the digits printed, within the range that was stated.
By their numbers in this assay, from the lowest: compounds 2, 3, 4 and 1 (each within the scatter of the next).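

In this assay, within the data shown here, methyl in place of hydrogen on an aromatic carbon, meta to a large group and opposite the ring nitrogen, gives a 1.1-fold higher number from compound 2 to compound 4 (0.03 log units; within the scatter), the first step that changes one place only. With the rest of compound 2 held fixed, this position therefore takes a methyl with no change beyond the scatter, whereas the methyl of compound 1 sits at a different place and comes with a different amine, so it could not be read on its own. No accompanying measurement bears on this result, and the step stands here without an explanation.

At this position the compounds shown carry only hydrogen and methyl, so it remains open whether a larger or different group, such as a carboxylic acid, an amine or a longer chain, would move the number beyond the scatter. From the compounds shown here alone, it also remains open whether the same methyl would leave the number equally unmoved alongside the amine parts of compound 1 and compound 3.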